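Aryl sulfonate series: from compound 1 to compound 4

The source may report more compounds than this note shows. Statements on the series, on what has been measured and on what is new or still open speak of the compounds shown alone.

Compound 1 `CCc1ccccc1OS(=O)(=O)c1ccc(N2CCN(C)C2=O)cc1` gives 2300 nM in a functional assay on M21 cells (Homo sapiens) for antiproliferative activity, read by sulforhodamine B assay, with a stated time of 48 h (on this read-out lower numbers stand for stronger inhibition and higher numbers for weaker inhibition), the highest of the three numbers in hand. Compound 3 `CN1CCN(c2ccc(S(=O)(=O)Oc3c(Cl)cc(Cl)cc3Cl)cc2)C1=O` gives 1700 nM, which lies within the scatter of compound 1, while compound 2 `CN1CCN(c2ccc(S(=O)(=O)Oc3cc(Cl)c(Cl)cc3Cl)cc2)C1=O` gives 420 nM, a gap beyond the scatter. Compound 4 `CN1CCN(c2ccc(S(=O)(=O)Oc3ccc(F)cc3)cc2)C1=O` has not yet been measured. It differs from compound 1 in one place: 4-fluorophenyl in place of 2-ethylphenyl on an oxygen. Within the data shown here, no step between measured compounds that differ in one place is known, so the size of this change cannot be read from the series itself. The expected step is a small one toward lower numbers, a 1.5-fold lower number from compound 1 to compound 4 (0.19 log units; within the scatter), not clearly beyond the scatter. Compound 4 is estimated at 1500 nM, with a range from 500 nM to 4500 nM.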

Compound 4, half-maximal inhibitory concentration: > 100000 nM
Compound 4 gave a limit, no number; the forecaster's own chance of this, stated with the estimate: 5%; middle value at least 66-fold (1.82 log units) away from the limit.
By their numbers in this assay, from the lowest: compound 2; then compounds 3 and 1 (each within the scatter of the next). At a limit, above all of these: compound 4.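

On the oxygen bound to the sulfonyl sulfur, the exchange of 2-ethylphenyl for 4-fluorophenyl in this assay gives an at least 43-fold higher number from compound 1 to compound 4 (1.63 log units; beyond the scatter). Among these compounds, this is the first one-place step, and it shows that this place alone, with the shared core unchanged, can decide the read-out. Compound 4 stands at a limit, not a number: the limit of > 100000 nM in this assay, at which 1 of the 4 values shown sits.

The two groups differ in both the substituent and the place it occupies on the ring, and the compounds shown do not separate these. Also open, as far as these compounds go, is how 2-fluorophenyl, 4-ethylphenyl or unsubstituted phenyl would stand on this oxygen.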